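A few compounds are considered here, and "the series" means these few. Any claim that something is new, unique, unknown or untested is made for them only; others in the source may bear on it.

For the measured compounds named here, compound 2 `CNC(=O)Nc1c(C)nc2c(OCc3ccccc3)cccn12` gives 22% in a functional assay on the whole organism with Rattus norvegicus as the target, at a dose of 40 mg/kg by the intraperitoneal route (a higher number here means more inhibition at the dose given (going by the name of the read-out), a lower number less inhibition), the higher of the two numbers so far; compound 1 `Cc1nc2c(OCc3ccccc3)cccn2c1NC(=O)OCc1ccccc1` gives 8%. Going by the values given here, the one measured step, a number 14 percentage points higher from compound 1 to compound 2 (beyond the scatter), alters only the group on the carbonyl carbon. Among the compounds with values here, compound 3 `Cc1nc2c(OCc3ccccc3)cccn2c1N(C)C` differs from compound 2 by dimethylamino in place of (methylcarbamoyl)amino on an aromatic carbon, which removes the carbonyl and the hydrogen-bond donors; no measured step covers a change of this kind, so guidance is thin. Within the data shown here, both numbers so far are low, and compound 3 is expected to stay near them, with an expected step of a number 10 percentage points lower from compound 2 to compound 3 (within the scatter). Compound 3 is estimated at 12%, between 0% and 30%.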

Compound 3, a percentage reported as inhibition, in the whole organism at one dose (the size of the read-out at that dose, not a potency): 76%
Beside the measured number, compound 3's estimate is 64 percentage points below it; the whole stated range lies below it.
By their numbers in this assay, from the lowest: compound 1; then compound 2; then compound 3.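

Replacing (methylcarbamoyl)amino with dimethylamino on this aromatic carbon gives a number 54 percentage points higher from compound 2 to compound 3 (beyond the scatter) in this assay, a far larger change than a number 14 percentage points higher from compound 1 to compound 2 (beyond the scatter) seen when only the group on the carbonyl carbon differed. A carbonyl on this nitrogen is therefore not required for a high number in this series. No available evidence explains the size of this step.

The compounds shown leave open whether the gain follows loss of the carbonyl or the hydrogen-bond donors. Methylamino, an unsubstituted amine or diethylamino at this position could separate these possibilities.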